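The source may report more compounds than this note shows. Statements on the series, on what has been measured and on what is new or still open speak of the compounds shown alone.

Measured in a functional assay on MDA-MB-231 cells (Homo sapiens) for inhibition, read by sulforhodamine B assay, with a stated time of 48 h, tested at 10 uM; on this read-out higher numbers stand for more inhibition at the one concentration tested (going by the name of the read-out) and lower numbers for less inhibition:

compound 1 `c1ccc(-c2cn3ccnc3c(-c3ccc4ncn(C5CCCCC5)c4c3)n2)cc1`: 41.5%
compound 2 `Fc1ccc(-c2cn3ccnc3c(-c3ccc4ncn(C5CCCCC5)c4c3)n2)cc1`: 15.8%
compound 3 `Brc1ccc(-c2cn3ccnc3c(-c3ccc4ncn(C5CCCCC5)c4c3)n2)cc1`: 22.8%

Compound 3 stands second highest of the three numbers in this assay, within the scatter of compound 2 and beyond the scatter below compound 1. Within the data shown here, the only changes measured so far concern the group on the phenyl ring: a number 25.7 percentage points lower from compound 1 to compound 2 (beyond the scatter) and a number 18.7 percentage points lower from compound 1 to compound 3 (beyond the scatter), both modest and both lowering, while a number 7 percentage points higher from compound 2 to compound 3 (within the scatter) stays within the scatter.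

Compound 4 `COc1ccccc1-c1cn2ccnc2c(-c2ccc3ncn(C4CCCCC4)c3c2)n1` differs from compound 3 by 2-methoxyphenyl in place of 4-bromophenyl on an aromatic carbon. Among the measured compounds shown here, no measured step covers a methoxy group or a group at this position of the phenyl ring, so the estimate rests on the finding that removing the halogen from compound 3 would return to compound 1, whose inhibition is higher. Compound 4 is therefore expected to land between compound 3 and compound 1, the expected step being a number 7.2 percentage points higher from compound 3 to compound 4 (within the scatter), with wide uncertainty. The estimate for compound 4 in this assay is 30%, ranging from 10% to 55%.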

Compound 4, a percentage reported as inhibition, at one concentration (the size of the read-out at that concentration, not a potency): 15.9%
Compound 4: the middle estimate sits 14.1 percentage points above what was measured; the range from low to high includes it.
By their numbers in this assay, from the lowest: compounds 2, 4 and 3 (each within the scatter of the next); then compound 1.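

In this assay, a number 25.6 percentage points lower from compound 1 to compound 4 (beyond the scatter) shows that the loss seen with the two halogens on the phenyl ring also occurs with a methoxy group, in 2-methoxyphenyl rather than a 4-halophenyl group. Both a number 6.9 percentage points lower from compound 3 to compound 4 (within the scatter) and a number 0.1 percentage points higher from compound 2 to compound 4 (within the scatter) leave 2-methoxyphenyl indistinguishable in this read-out from 4-bromophenyl and 4-fluorophenyl, so all three substituted compounds sit together, beyond the scatter from compound 1. Nothing available explains this shared difference from the unsubstituted phenyl group.

The compounds shown do not separate the kind of group from its place on the phenyl ring, as the methoxy group and the halogens occupy different places. From the compounds shown here alone, how an amine or a carboxylic acid on that ring would compare with the unsubstituted phenyl of compound 1 also remains open.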